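Trimming a Methoxy from an Aryl-Amino Side Chain

The source may report more compounds than this note shows. Statements on the series, on what has been measured and on what is new or still open speak of the compounds shown alone.

Measured so far:
compound 1, `C=C1[C@@H](OC(C)=O)C[C@@H]2[C@](C)(CO[Si](C)(C)C(C)(C)C)[C@H](OC(C)=O)CC[C@@]2(C)[C@@H]1C[C@@H](Nc1ccc(OC)c(OC)c1)C1=CCOC1=O`, 4870 nM
compound 2, `C=C1[C@@H](OC(C)=O)C[C@@H]2[C@](C)(COC=O)[C@H](OC(C)=O)CC[C@@]2(C)[C@@H]1C[C@@H](Nc1cccc2ccccc12)C1=CCOC1=O`, 35600 nM

Both compounds were tested in a functional assay on A549 cells (Homo sapiens) for cytotoxicity, read by sulforhodamine B assay; a lower number here means a stronger inhibitor, a higher number a weaker inhibitor. Compound 1 gives the lower of the two numbers, and compound 2 gives a number that lies beyond the scatter above it. Going by the values given here, no step between the two is worked out, since they differ in more than one place, so only the two values themselves can be compared.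

Compound 3, `C=C1[C@@H](OC(C)=O)C[C@@H]2[C@](C)(CO[Si](C)(C)C(C)(C)C)[C@H](OC(C)=O)CC[C@@]2(C)[C@@H]1C[C@@H](Nc1cccc(OC)c1)C1=CCOC1=O`, has not yet been measured. It differs from compound 1 in one place only: hydrogen in place of methoxy on an aromatic carbon. Among the compounds with values here, nothing among the measured compounds shows what this single change does, so any expectation rests on the change itself being small.

The step of a 1.4-fold higher number from compound 1 to compound 3 (0.16 log units; within the scatter) is expected to be modest, likely a somewhat higher number, possibly within the scatter. Compound 3 is therefore estimated at 7000 nM, with a range from 2500 nM to 20000 nM.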

Compound 3, half-maximal inhibitory concentration: 17200 nM
For compound 3 the middle estimate is 2.5-fold (0.39 log units) below the measured one, and the stated range covers the measured number.
By their numbers in this assay, from the lowest: compound 1; then compound 3; then compound 2.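

Replacing methoxy with hydrogen on this aromatic carbon, which turns 3,4-dimethoxyphenyl into 3-methoxyphenyl, gives a 3.5-fold higher number from compound 1 to compound 3 (0.55 log units; beyond the scatter) in this assay. This shows that the position is not indifferent: with the rest of the molecule unchanged, keeping the methoxy group here goes with stronger cytotoxicity. Compound 1 and compound 2 differ in more than one place, so they could not tie a change in cytotoxicity to any single group, and no measurement here explains why this one matters.

From the compounds shown here alone, it remains open whether the oxygen, the methyl or the whole methoxy group matters here, which a hydroxyl or an ethoxy group at this carbon could help to separate. Going by these compounds, the contribution of the remaining methoxy group also remains unknown, as does whether this step would hold on a different side of the shared core.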